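This account rests on a few compounds, and the source may have more. Where it says the series, first, only, none or still open, it means among the compounds named here.

Series in a functional assay on the whole organism (strain Wistar) with Rattus norvegicus as the target, read by paw edema, at a dose of 30 mg/kg by the oral route; on this read-out higher numbers stand for an effect only at larger amounts of compound and lower numbers for an effect already at smaller amounts:

- compound 1 `NS(=O)(=O)c1ccc(-n2nc(C(F)(F)F)cc2-c2ccc(Br)cc2)cc1CO`: 35 mg/kg
- compound 2 `NS(=O)(=O)c1ccc(-n2nc(C(F)F)cc2-c2ccc(Br)cc2)cc1CO`: 42 mg/kg
- compound 3 `CCC(=O)OCc1cc(-n2nc(C(F)F)cc2-c2ccc(Br)cc2)ccc1S(N)(=O)=O`: not yet measured

Within the data shown here, compound 2 at 42 mg/kg cannot be told apart from compound 1, the only other measured compound, as the two lie within the scatter of each other.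

The next structure carries propanoyl in place of hydrogen on an oxygen on a saturated carbon: hydroxymethyl to (propanoyloxy)methyl, with propanoyl in place of hydrogen on an oxygen on a saturated carbon. Among the measured compounds shown here, the one measured step, a 1.2-fold higher number from compound 1 to compound 2 (0.08 log units; within the scatter), is a different change at a different place, so it bears only loosely on this one. For the measured compounds named here, no measured compound shows what this change does in this assay.

Going by the values given here, with no precedent, neither direction is favoured, and no shift beyond the scatter is expected. The expected step is a 1.1-fold lower number from compound 2 to compound 3 (0.02 log units; within the scatter). Compound 3 is estimated at 40 mg/kg, with an expected range of 17 mg/kg to 95 mg/kg.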

Compound 3, dose for half-maximal effect: 40 mg/kg
Estimate against measurement, compound 3: no gap at the digits printed; low and high end bracket the measured number.
By their numbers in this assay, from the lowest: compounds 1, 3 and 2 (each within the scatter of the next).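

In this assay, among these compounds, propanoyl in place of hydrogen on the oxygen of the hydroxymethyl group gives a 1.1-fold lower number from compound 2 to compound 3 (0.02 log units; within the scatter), so this is the first reading at this oxygen, and (propanoyloxy)methyl cannot be told apart from hydroxymethyl here. The earlier step spoke only to fluoro on the chain carbon, so the series now has one step at each of two places, neither beyond the scatter, and the three compounds each lie within the scatter of the next. Nothing available explains why the number stays where it does.

The compounds shown leave open whether a longer chain such as butanoyl, or an amine or carboxylic acid in place of the hydroxymethyl group, would read the same. They also leave open whether propanoyl gives the same reading with trifluoromethyl in place of difluoromethyl.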